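Phenethyl to Benzyloxy: Expected Liver Microsome Stability

The compounds below may be only part of what the source reports. "The series", "measured", "known", "first", "only" and "open" are said of these compounds alone.

Three compounds sharing one core were tested in an ADME assay on microsomes from liver (Rattus norvegicus) for metabolic stability, with a stated time of 10 min; a higher number here means that more of the compound is left, a lower number that less of the compound is left. Compound 1 `CCOc1nn2cc(-c3cc4ccccc4o3)nc2s1` gives 37%. Compound 3 `COc1ccc2oc(-c3cn4nc(OC)sc4n3)cc2c1` gives 38%. Compound 2 `COc1cc(OCc2cccc(CCc3ccccc3)c2)c2cc(-c3cn4nc(OC)sc4n3)oc2c1` gives 68%, the highest of the three numbers, and its gaps to compound 3 and to compound 1 both lie beyond the scatter, so compound 2 is the most stable of the measured set. Compound 4 `COc1cc(OCc2cccc(OCc3ccccc3)c2)c2cc(-c3cn4nc(OC)sc4n3)oc2c1` has not yet been measured. It differs from compound 2 in one place: benzyloxy in place of phenethyl on an aromatic carbon. Within the data shown here, no measured pair shows what such a change does, so the expectation rests on compound 2 alone. In this assay the step of a number 8 percentage points lower from compound 2 to compound 4 (within the scatter) is expected to be small, at most a slight downward move near the scatter. Compound 4 is therefore estimated at 60%, with a range from 40% to 78%.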

Compound 4, percent of the compound remaining: 76%
Compound 4: middle estimate off by 16 percentage points, on the low side; the measured number falls inside the stated range.
By their numbers in this assay, from the lowest: compounds 1 and 3 (each within the scatter of the next); then compounds 2 and 4 (each within the scatter of the next).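

In this assay, among these compounds, the step of a number 8 percentage points higher from compound 2 to compound 4 (within the scatter) gives the first direct reading of a change at this position. On this aromatic carbon, meta to a large group, benzyloxy in place of phenethyl adds a hydrogen-bond acceptor, yet the two compounds cannot be told apart in this read-out. No measurement shown here bears on the reason for this result. From the compounds shown here alone, it remains open whether an amine, a carboxylic acid or a longer chain on this same aromatic carbon would also leave the number within the scatter.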